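This account rests on a few compounds, and the source may have more. Where it says the series, first, only, none or still open, it means among the compounds named here.

Compound 1 `O=C(CI)NCCCN(O)C(=O)/C=C/c1ccc(Cl)cc1Cl` and compound 2 `O=C(/C=C/c1ccc(Cl)cc1Cl)N(O)CCCN1C(=O)C=CC1=O` have both been read in a physicochemical assay for solubility, read by spectrophotometry, with a stated time of 2 h; on this read-out lower numbers stand for lower solubility and higher numbers for higher solubility. Compound 1 gives >= 200000 nM, which is a limit and not a number. Compound 2 gives >= 200000 nM, also a limit, so it stands only at a bound and has no exact value. The evidence so far is the limit of >= 200000 nM in this assay, at which 2 of the 2 values shown sit. Compound 3 `O=C(/C=C/c1ccc(Cl)cc1Cl)N(O)CCCCCC1CO1` is the next to be read, and its structural change is a group of 5 heavy atoms (4 carbon, 1 oxygen; one three-membered non-aromatic ring with 1 hetero atom) in place of a group of 7 heavy atoms (4 carbon, 1 nitrogen, 2 oxygen; one five-membered non-aromatic ring with 1 hetero atom), on a saturated chain carbon, three bonds along the chain from an amide-type nitrogen. The group with the five-membered non-aromatic ring gives way to 2-(oxiran-2-yl)ethyl, on a saturated chain carbon, three bonds along the chain from an amide-type nitrogen. For the measured compounds named here, the only measured step, a step that the two limits leave unreadable from compound 1 to compound 2, offers no size to carry over, so no step beyond the scatter is expected in this assay. The expected step is an at least 1.1-fold lower number from compound 2 to compound 3 (0.04 log units; that floor lies within the scatter). For compound 3 the estimate is 180000 nM, with an expected range from 70000 nM to 200000 nM.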

Compound 3, solubility: >= 200000 nM
Compound 3: no number, only a limit; the forecaster's own chance of this, stated with the estimate: 65%; at least 1.1-fold (0.04 log units) between middle value and limit.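

In this assay, for the compounds shown here, compound 3 gives >= 200000 nM, a limit and not a number, so no step among compound 1, compound 2 and compound 3 can be read. The compounds shown leave open how their solubilities compare beyond this limit.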